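The source may report more compounds than this note shows. Statements on the series, on what has been measured and on what is new or still open speak of the compounds shown alone.

Working notes on the series. In a functional assay on A549 cells (Homo sapiens) for cytotoxicity, read by MTT assay, with a stated time of 48 h (a higher number here means a weaker inhibitor, a lower number a stronger inhibitor), compound 1 (`COc1cc(-n2c(-c3ccc(O)cc3)c[nH]c2=O)cc(OC)c1OC`) gives > 50000 nM, which is a limit of the assay and not a number. Compound 2 (`COc1ccc(-c2c[nH]c(=O)n2-c2cc(OC)c(OC)c(OC)c2)cc1`) gives > 50000 nM, again a limit. Compound 2 therefore stands at the limit of > 50000 nM in this assay, at which 2 of the 2 values shown sit, with no number of its own.

Compound 3 (`COc1ccc(-c2cn(C(C)=O)c(=O)n2-c2cc(OC)c(OC)c(OC)c2)cc1`) differs from compound 2 in one place: acetyl in place of hydrogen on an aromatic nitrogen. Among the measured compounds shown here, the only measured step is a step that the two limits leave unreadable from compound 1 to compound 2. It involves an oxygen rather than this nitrogen and offers no size to carry over. In this assay a readable step could only be expected towards stronger inhibition, and remaining at the limit is about as likely. The expected change is an at least 2.0-fold lower number from compound 2 to compound 3 (0.30 log units; that floor lies within the scatter). For compound 3 the estimate is 25000 nM, within an expected range of 2000 nM to 50000 nM.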

Compound 3, half-maximal inhibitory concentration: 17800 nM
For compound 3 the middle estimate is 1.4-fold (0.15 log units) above the measured one, within the range that was stated.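

Acetyl in place of hydrogen on the aromatic nitrogen gives the first readable step of the series in this assay: an at least 2.8-fold lower number from compound 2 to compound 3 (0.44 log units; beyond the scatter). This size is only a floor, as the starting value is a limit of the assay and not a number, so the true step may be larger. A change at this nitrogen thus moves the read-out off the limit, whereas the one step at an oxygen cannot be read, and the other two compounds stay there: the limit of > 50000 nM in this assay, at which 2 of the 3 values shown sit.

As far as these compounds go, it remains open whether this shift belongs to acetyl itself or would also follow from a simple methyl, a longer acyl chain such as butanoyl, or a benzoyl group on the same nitrogen. From the compounds shown here alone, it is equally open whether acetyl at this position would have a similar effect on compound 1.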